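The source may report more compounds than this note shows. Statements on the series, on what has been measured and on what is new or still open speak of the compounds shown alone.

Working notes on the series. The shared core is that of compound 1 `CC(=O)c1c(NNc2ccccc2)cc(C)oc1=O`, which in a functional assay on the whole organism for inhibition, with Rattus norvegicus as the target, read by paw edema, with a stated time of 2 h, at a dose of 50 mg/kg (a higher number here means more inhibition at the dose given (going by the name of the read-out), a lower number less inhibition), gives 57.3%. Compound 2 `CC(=O)c1c(NNc2ccc(C)cc2)cc(C)oc1=O` carries methyl in place of hydrogen on an aromatic carbon; in this assay compound 2 gives 53.4%, the step being a number 3.9 percentage points lower from compound 1 to compound 2 (within the scatter). Compound 3 `CC(=O)c1c(NNc2ccc(Cl)cc2)cc(C)oc1=O` carries chloro in place of hydrogen on an aromatic carbon; in this assay compound 3 gives 57.3%. From compound 1 the step is no change at the digits printed from compound 1 to compound 3 (within the scatter), and from compound 2 it is a number 3.9 percentage points higher from compound 2 to compound 3 (within the scatter). Compound 3 therefore stands level with compound 1 as far as the digits go, the two sharing the highest of the three numbers, and compound 2 is not separated from either beyond the scatter.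

Compound 4 `CC(=O)c1c(NNc2ccc(Br)cc2)cc(C)oc1=O` differs from compound 3 by bromo in place of chloro on an aromatic carbon. For the measured compounds named here, the steps that bear on this are the three substitutions on an aromatic carbon already measured, and none of them moved beyond the scatter. No exchange of chloro for bromo has been measured in the series. The step from compound 3 to compound 4 in this assay is therefore expected to be a number 0.3 percentage points lower from compound 3 to compound 4 (within the scatter), nothing beyond the scatter. Compound 4 is estimated to give 57%, with a range from 47% to 67%.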

Compound 4, a percentage reported as inhibition, in the whole organism at one dose (the size of the read-out at that dose, not a potency): 47.2%
Compound 4: middle estimate off by 9.8 percentage points, on the high side, and the stated range covers the measured number.
By their numbers in this assay, from the lowest: compounds 4, 2, 1 and 3 (each within the scatter of the next, the first and the last beyond it).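

At this place, on the aromatic carbon para to a large group, the substituent can matter in this assay: the exchange of chloro for bromo gives a number 10.1 percentage points lower from compound 3 to compound 4 (beyond the scatter) and so does not behave like the earlier substitutions, none of which left the scatter. Bromo in place of hydrogen gives the same size of step, a number 10.1 percentage points lower from compound 1 to compound 4 (beyond the scatter) and thus a modest separation from the unsubstituted compound, so chloro and bromo, although both halogens, do not read alike here. Bromo in place of methyl gives a number 6.2 percentage points lower from compound 2 to compound 4 (within the scatter) and so does not separate the two, which leaves compound 2 unresolved from every other compound and limits any ranking to the modest gaps of compound 4 from compound 1 and compound 3. The data at hand offer no measurement that would explain the difference between bromo and chloro.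

The compounds shown leave open whether the lower number is particular to bromo or would recur with fluoro, iodo, methoxy or an amine at this place. They also leave open how the same exchange reads at a different dose or time in the same model.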